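Adding methyl groups to the thiophene of compound 3

The source may hold more compounds than are shown below. What is called first, only, known or untested is meant among the compounds shown, and "the series" means these compounds.

Measured so far in a functional assay on cells (Cancer cell lines, Homo sapiens) for inhibition (on this read-out lower numbers stand for stronger inhibition of growth and higher numbers for weaker inhibition of growth), are three compounds.
Compound 1 `Cc1cn2c(/C=N/Nc3ccccn3)c(-c3ccc(Cl)c([N+](=O)[O-])c3)nc2s1` gives 15500 nM
Compound 2 `N=C(N)N/N=C/c1c(-c2cc(Cl)sc2Cl)nc2n1CCS2` gives 10000 nM
Compound 3 `N=C(N)N/N=C/c1c(-c2ccsc2)nc2n1CCS2` gives 28200 nM

Compound 3 lies within the usual scatter of compound 1, while compound 2 shows a lower number than compound 3. Compound 4 `Cc1cc(-c2nc3n(c2/C=N/NC(=N)N)CCS3)c(C)s1` keeps the shared core but has 2,5-dimethylthiophen-3-yl in place of thiophen-3-yl on an aromatic carbon. Among the measured compounds shown here, one measured step bears on this. Read in reverse, the step that drops the 2,5-dichlorothiophen-3-yl group (a 2.8-fold higher number from compound 2 to compound 3 (0.45 log units; beyond the scatter)) leads to expecting a modest fall in the number in this assay, though methyl groups are not chlorines and no measured compound carries them. The expected size is a 1.9-fold lower number from compound 3 to compound 4 (0.27 log units; within the scatter) in this reading. For compound 4 the estimate is 15000 nM with an expected range from 6000 nM to 35000 nM on this read-out.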

Compound 4, concentration for 50% growth inhibition: 17400 nM
Compound 4: middle estimate off by 1.2-fold (0.06 log units), on the low side; low and high end bracket the measured number.
By their numbers in this assay, from the lowest: compounds 2, 1, 4 and 3 (each within the scatter of the next, the first and the last beyond it).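

In this assay, the 2,5-dimethylthiophen-3-yl group on this aromatic carbon gives a 1.6-fold lower number from compound 3 to compound 4 (0.21 log units; within the scatter) and a 1.7-fold higher number from compound 2 to compound 4 (0.24 log units; within the scatter), so compound 4 cannot be told apart from either neighbour. Compound 2 and compound 3 do differ, with a 2.8-fold higher number from compound 2 to compound 3 (0.45 log units; beyond the scatter), so the two methyl groups leave that gap unresolved. No measurement on hand explains this result.

On these data alone, whether one methyl group alone would behave like two stays open. So does what an amine or a carboxylic acid on the thiophene would do to growth inhibition.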